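The source may report more compounds than this note shows. Statements on the series, on what has been measured and on what is new or still open speak of the compounds shown alone.

Compound 1 `CCCS(=O)(=O)Nc1ccc(F)c(C(=O)c2n[nH]c3ncc(-c4cccc(Cl)c4)cc23)c1F` is one of three compounds that share a core and differ only in the aryl group attached to it. In an assay for binding affinity to dual specificity mitogen-activated protein kinase kinase 4 (Homo sapiens), read by KINOMEscan, tested at 100 nM (a higher number here means a weaker effect of the compound at the concentration tested, a lower number a stronger effect), compound 1 gives 40%, the second highest of the three numbers. Compound 2 `CCCS(=O)(=O)Nc1ccc(F)c(C(=O)c2n[nH]c3ncc(-c4cccc(O)c4)cc23)c1F` carries a hydroxy in place of the chloro and gives 2.2%, so a number 37.8 percentage points lower from compound 1 to compound 2 (beyond the scatter). Compound 3 `CCCS(=O)(=O)Nc1ccc(F)c(C(=O)c2n[nH]c3ncc(-c4cc(Cl)cc(Cl)c4)cc23)c1F` carries a second chloro and gives 73%, so a number 33 percentage points higher from compound 1 to compound 3 (beyond the scatter) and, between the two outer compounds, a number 70.8 percentage points higher from compound 2 to compound 3 (beyond the scatter).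

Compound 4 `CCCS(=O)(=O)Nc1ccc(F)c(C(=O)c2n[nH]c3ncc(-c4ccc(Cl)c(Cl)c4)cc23)c1F` is not yet measured. It differs from compound 1 in this way: chloro in place of hydrogen on an aromatic carbon. The entering chloro sits on an aromatic carbon of the six-membered carbon ring, ortho to the chloro already there and para to a large group. The step from compound 1 to compound 3 is the one that bears on it, as it also puts a chloro in place of hydrogen on that ring, and it raised the number by a large margin. A second chloro at a different place need not do the same, but a rise beyond the scatter is the reasonable expectation. The estimate for compound 4 is therefore 65%, within 45% to 85%, meaning a number 25 percentage points higher from compound 1 to compound 4 (beyond the scatter).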

Compound 4, a percentage reported as activity, at one concentration (the size of the read-out at that concentration, not a potency): 45%
Compound 4: the middle estimate sits 20 percentage points above what was measured; the measured number falls inside the stated range.
By their numbers in this assay, from the lowest: compound 2; then compounds 1 and 4 (each within the scatter of the next); then compound 3.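

A second chloro on this ring does not always shift the read-out: placed ortho to the chloro already there and para to a large group, it gives a number 5 percentage points higher from compound 1 to compound 4 (within the scatter) in this assay, so compound 1 and compound 4 cannot be told apart here. Where the second chloro sits therefore matters, which compound 3 alone could not show, as moving from one dichlorophenyl pattern to the other gives a number 28 percentage points lower from compound 3 to compound 4 (beyond the scatter) and the step is beyond the scatter. Compound 4 also stays well apart from the hydroxy compound, with a number 42.8 percentage points higher from compound 2 to compound 4 (beyond the scatter) as the step between them, and no measurement is at hand that would explain any of these differences.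

Still open, from the compounds shown here alone, is whether a fluoro, a methyl or a methoxy at the carbon para to a large group would also leave the number in this assay close to that of compound 1, or whether this holds only for chloro. Also open, going by these compounds, is whether a hydroxy or an amine at that same carbon would give a number as low as that of compound 2, with its hydroxy at a different place on the ring.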